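The source may hold more compounds than are shown below. What is called first, only, known or untested is meant among the compounds shown, and "the series" means these compounds.

Measured in a functional assay on CCRF-CEM cells (Homo sapiens) for antiproliferative activity; on this read-out lower numbers stand for stronger inhibition of growth and higher numbers for weaker inhibition of growth:
- Compound 1 `COCCCCCCCCCCCCCCC/C=C1\CC(CO)(COC(=O)C(C)(C)C)OC1=O` – 4.26 ug/mL
- Compound 2 `CCCCCOCCCCCCC/C=C1\CC(CO)(COC(=O)C(C)(C)C)OC1=O` – 0.877 ug/mL
- Compound 3 `CC(C)(C)C(=O)OCC1(CO)C/C(=C\CCCCCCCCCCCO)C(=O)O1` – 0.65 ug/mL

Compound 3, at 0.65 ug/mL, sits at the low end of these numbers, alongside compound 2. The gap between them, a 1.3-fold lower number from compound 2 to compound 3 (0.13 log units; within the scatter), stays within the scatter, so neither can be ranked over the other. Compound 1 stands apart, and a 6.6-fold lower number from compound 1 to compound 3 (0.82 log units; beyond the scatter) lies beyond the scatter.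

The next compound to be tested is compound 4 `CC(=O)NCCCCCCCCCCCCCCC/C=C1\CC(CO)(COC(=O)C(C)(C)C)OC1=O`. Its structural change from compound 3 is 4-acetamidobutyl in place of hydroxy on a saturated chain carbon, ten or more bonds along the chain from a double-bonded chain carbon.

The closest guide is the step already quoted from compound 1, which puts hydroxy in place of 4-methoxybutyl at this same place. Compound 4 runs the opposite way, with 4-acetamidobutyl in place of hydroxy. A second modest step, a 4.9-fold lower number from compound 1 to compound 2 (0.69 log units; beyond the scatter), also starts from compound 1 and lowers the number. For the measured compounds named here, no measured compound carries an acetamido group, so the parallel with compound 1 is only partial.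

A modest rise is therefore expected in this assay, towards weaker inhibition of growth, and the expected step is a 4.6-fold higher number from compound 3 to compound 4 (0.66 log units; beyond the scatter). Compound 4 is estimated at 3 ug/mL, with an expected range of 0.9 ug/mL to 10 ug/mL.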

Compound 4, concentration for 50% growth inhibition: 1.08 ug/mL
Beside the measured number, compound 4's estimate is 2.8-fold (0.44 log units) above it; the measured number falls inside the stated range.
By their numbers in this assay, from the lowest: compounds 3, 2 and 4 (each within the scatter of the next); then compound 1.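

In this assay, placing 4-acetamidobutyl in place of hydroxy on a saturated chain carbon, ten or more bonds along the chain from a double-bonded chain carbon, leaves the number within the scatter (a 1.7-fold higher number from compound 3 to compound 4 (0.22 log units; within the scatter)). So this far end of the chain accepts an amide-bearing extension with no readable loss, and compound 4 also cannot be separated from compound 2 (a 1.2-fold higher number from compound 2 to compound 4 (0.09 log units; within the scatter)). The comparison with compound 1 adds the clearest new point, as acetamido in place of methoxy at the end of the chain gives a change beyond the scatter (a 3.9-fold lower number from compound 1 to compound 4 (0.60 log units; beyond the scatter)), which shows that the weaker result of compound 1 does not follow from chain length alone, since the group at the chain end also counts; nothing given here explains this difference.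

From the compounds shown here alone, what a free amine or a carboxylic acid at the same chain end would give remains open. Going by these compounds, it is also open whether hydroxy on the full-length chain of compound 4 would match acetamido, and whether a longer chain ending in acetamido would keep the number within the scatter of compound 4.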